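The source may report more compounds than this note shows. Statements on the series, on what has been measured and on what is new or still open speak of the compounds shown alone.

Measured compounds:
Compound 1, `Cn1c(-c2ccc(NC(=O)CSc3nc4ccccc4o3)cc2)nc(-c2ccccc2)c1-c1ccccc1`, gives 56.2%.
Compound 2, `Cc1ccc2oc(SCC(=O)Nc3ccc(-c4nc(-c5ccccc5)c(-c5ccccc5)n4C)cc3)nc2c1`, gives 37.7%.
Compound 3, `Cn1c(-c2ccc(NC(=O)CSc3nc4ccccc4s3)cc2)nc(-c2ccccc2)c1-c1ccccc1`, gives 47.2%.

All three were tested in a functional assay on HT-29 cells (Homo sapiens) for cytotoxicity, read by MTT assay, with a stated time of 24 h, tested at 16 ug/mL; on this read-out higher numbers stand for a stronger effect at the one concentration tested and lower numbers for a weaker effect. Compound 3 stands second highest of the three numbers; its nearest neighbour is compound 1 and its furthest is compound 2, and both of its steps to them fall within the scatter: a number 9 percentage points lower from compound 1 to compound 3 (within the scatter) and a number 9.5 percentage points higher from compound 2 to compound 3 (within the scatter). Going by the values given here, the only step beyond the scatter in this set is a number 18.5 percentage points lower from compound 1 to compound 2 (beyond the scatter), which touches the same heteroaryl on the sulfur.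

Compound 4, `Cn1cnnc1SCC(=O)Nc1ccc(-c2nc(-c3ccccc3)c(-c3ccccc3)n2C)cc1`, has not yet been measured. It differs from compound 3 in one place: 4-methyl-4H-1,2,4-triazol-3-yl in place of 1,3-benzothiazol-2-yl on a sulfur. Among the compounds with values here, the two measured steps that vary the group on this sulfur both stayed within the scatter, while the single methyl in the step from compound 1 to compound 2 moved the number modestly. The change to compound 4 removes a larger group than either of those steps exchanged, so a modest step in this assay is expected, more likely downward than upward, though a result within the scatter cannot be ruled out. For compound 4 the estimated value is 38%, with a range from 20% to 58%, which means an expected step of a number 9.2 percentage points lower from compound 3 to compound 4 (within the scatter).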

Compound 4, a percentage reported as activity, at one concentration (the size of the read-out at that concentration, not a potency): 59.1%
Beside the measured number, compound 4's estimate is 21.1 percentage points below it; measured number outside the range, above it.
By their numbers in this assay, from the lowest: compounds 2, 3, 1 and 4 (each within the scatter of the next, the first and the last beyond it).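

In this assay, the result shows that the group on this sulfur need not be a fused pair of rings, since 4-methyl-4H-1,2,4-triazol-3-yl, a single five-membered aromatic ring, keeps the effect at the one concentration tested. Going by these compounds alone, the change from 1,3-benzothiazol-2-yl gives a number 11.9 percentage points higher from compound 3 to compound 4 (beyond the scatter) and is the first change of a group on this sulfur to go beyond the scatter from compound 3, while the change from 5-methyl-1,3-benzoxazol-2-yl gives a number 21.4 percentage points higher from compound 2 to compound 4 (beyond the scatter) and is the larger of the two. The single ring does not stand above every fused group, however: the change from 1,3-benzoxazol-2-yl gives a number 2.9 percentage points higher from compound 1 to compound 4 (within the scatter), so compound 1 goes against any rule that the single ring does better.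

No measurement shown here accounts for these steps. The compounds shown also leave open whether the methyl on the triazole ring matters, and how an amine or a carboxylic acid on that ring, or a longer chain in place of that methyl, would fare in this assay.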